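Swapping the Aryl Group on the Saturated Ring

The source may report more compounds than this note shows. Statements on the series, on what has been measured and on what is new or still open speak of the compounds shown alone.

Compound 1 `CC(C)c1ccc(C2(CNC(=O)Nc3c(C(C)C)cccc3C(C)C)CCCC2)cc1` is the starting point of this account. For the measured compounds named here, in an assay on microsomes for inhibition of acyl-CoA:cholesterol acyltransferase (Oryctolagus cuniculus) (on this read-out lower numbers stand for stronger inhibition and higher numbers for weaker inhibition), compound 1 gives 48 nM, which is the highest of the three numbers measured so far. Compound 2 `COc1cccc(C2(CNC(=O)Nc3c(C(C)C)cccc3C(C)C)CCCC2)c1` gives 13 nM in this assay, and compound 3 `CC(C)c1cccc(C(C)C)c1NC(=O)NCC1(c2ccccc2C(F)(F)F)CCCC1` gives 18 nM. Both departures from compound 1 lowered the number: a 3.7-fold lower number from compound 1 to compound 2 (0.57 log units; beyond the scatter) and a 2.7-fold lower number from compound 1 to compound 3 (0.43 log units; beyond the scatter). Between the two alternatives themselves the difference, a 1.4-fold higher number from compound 2 to compound 3 (0.14 log units; within the scatter), stays within the scatter.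

Compound 4 `CC(C)c1cccc(C(C)C)c1NC(=O)NCC1(c2cccc(N(C)C)c2)CCCC1` is the next variation, not yet measured. It differs from compound 1 in one place: 3-(dimethylamino)phenyl in place of 4-isopropylphenyl on a saturated ring carbon. Going by the values given here, of the measured steps, the one to compound 2 bears most directly on it, since both put a single group on a ring carbon of the phenyl in place of 4-isopropylphenyl, and that step lowered the number beyond the scatter. A similar modest lowering is therefore expected here, a 2.8-fold lower number from compound 1 to compound 4 (0.45 log units; beyond the scatter). Compound 4 is thus estimated to give 17 nM in this assay, within a range from 7 nM to 45 nM.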

Compound 4, half-maximal inhibitory concentration: 33 nM
Compound 4: middle estimate off by 1.9-fold (0.29 log units), on the low side; the measured number falls inside the stated range.
By their numbers in this assay, from the lowest: compounds 2, 3, 4 and 1 (each within the scatter of the next, the first and the last beyond it).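

Compound 4 shows that replacing 4-isopropylphenyl on this saturated ring carbon does not always move the number beyond the scatter: in this assay there is a 1.5-fold lower number from compound 1 to compound 4 (0.16 log units; within the scatter), and the comparison with the 2-(trifluoromethyl)phenyl analogue gives a 1.8-fold higher number from compound 3 to compound 4 (0.26 log units; within the scatter). For the compounds shown here, the group on the aromatic ring also matters, since exchanging methoxy for dimethylamino gives a 2.5-fold higher number from compound 2 to compound 4 (0.40 log units; beyond the scatter), the first change made on the aromatic ring alone. No measurement at hand accounts for this gap between methoxy and dimethylamino.

The compounds shown leave open whether a primary amine or a hydroxyl group on that aromatic carbon would give a number closer to that of compound 2 or compound 4. Nor do they show how a carboxylic acid or a longer alkoxy chain there would fare.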